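Bromo for methoxy on the aryl ring of compound 2

A few compounds are considered here, and "the series" means these few. Any claim that something is new, unique, unknown or untested is made for them only; others in the source may bear on it.

Measured in a functional assay on HeLa cells (Homo sapiens) for antiproliferative activity, read by MTT assay, with a stated time of 48 h (a lower number here means a stronger inhibitor of growth, a higher number a weaker inhibitor of growth), so far:
compound 1, `Cc1cc2c(c(=O)n1C)C(c1ccc(C(C)C)cc1)C(C#N)=C(N)O2`: > 100000 nM, a limit of the assay rather than a number.
compound 2, `COc1cc(C2C(C#N)=C(N)Oc3cc(N(C)C)ccc32)cc(OC)c1OC`: 17 nM
compound 3, `Cc1cc2c(c(=O)n1C)C(c1cccc([N+](=O)[O-])c1)C(C#N)=C(N)O2`: 35000 nM

Compound 2 gives the lowest of the two numbers; the nearest number, from compound 3, lies far higher, well beyond the scatter. Compound 1 sits at the limit of > 100000 nM in this assay, at which 1 of the 3 values shown sits. Compound 2 thus stands alone in strength among these three, and nothing about shared features can be drawn from so few cases.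

Compound 4, `COc1cc(C2C(C#N)=C(N)Oc3cc(N(C)C)ccc32)cc(Br)c1OC`, differs from compound 2 in one place: bromo in place of methoxy on an aromatic carbon. Among the compounds with values here, no pair of measured compounds differing in a single place is available, so the size of this step has no direct precedent here. The expectation is a moderate loss in this assay, on the order of the usual scatter or somewhat beyond it, in the direction of a higher number.

For compound 4 the estimated value in this assay is 60 nM, with a range from 15 nM to 300 nM. The expected step from compound 2 to compound 4 is a 3.5-fold higher number from compound 2 to compound 4 (0.55 log units; beyond the scatter).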

Compound 4, concentration for 50% growth inhibition: 7 nM
For compound 4 the middle estimate is 8.6-fold (0.93 log units) above the measured one; measured number outside the range, below it.
By their numbers in this assay, from the lowest: compound 4; then compound 2; then compound 3. At a limit, above all of these: compound 1.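

In this assay, the methoxy ortho to a methoxy group and meta to a large group is not needed for strength: bromo in its place gives a 2.4-fold lower number from compound 2 to compound 4 (0.39 log units; beyond the scatter). Within the data shown here, this is the only single-place step, and it shows that this aromatic carbon tolerates a change from a group with one hydrogen-bond acceptor to one with none, with no loss in growth inhibition. No measurement at hand bears on why the number moves in this direction.

On these data alone, how chloro, ethoxy or an amine would behave on this same carbon stays open. Also open, as far as these compounds go, is whether the step carries over to other cores, since compound 1 and compound 3 differ from compound 2 in more than one place.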